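Oxan-4-yl for isopropyl: solubility at the assay ceiling

The source may report more compounds than this note shows. Statements on the series, on what has been measured and on what is new or still open speak of the compounds shown alone.

Two close relatives on the shared core have been measured in a physicochemical assay for solubility, in phosphate buffer, at pH 7.4; a lower number here means a less soluble compound, a higher number a more soluble compound. Compound 1, `COC(=O)N1CCN([C@H]2CC[C@H](Nc3ncnn4ccc([C@H](C)CC(N)=O)c34)CC2)CC1`, returns a limit of the assay rather than a number: in this assay compound 1 gives > 1000000 nM. Compound 2, `CC(=O)N1CCN([C@H]2CC[C@H](Nc3ncnn4ccc(C(C)C)c34)CC2)CC1`, likewise stops at a limit: in this assay compound 2 gives > 952000 nM. Where compound 2 stands can thus be stated only as a range, its solubility being given solely by the limit of > 952000 nM in this assay, at which 1 of the 2 values shown sits. Within the data shown here, no step between compound 1 and compound 2 can be sized, because both values are limits the limit of > 1000000 nM in this assay, at which 1 of the 2 values shown sits, and (the limit of > 952000 nM in this assay, at which 1 of the 2 values shown sits).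

Compound 3, `CC(=O)N1CCN([C@H]2CC[C@H](Nc3ncnn4ccc(C5CCOCC5)c34)CC2)CC1`, has not yet been measured. It differs from compound 2 in a single place: oxan-4-yl in place of isopropyl on an aromatic carbon. Among the measured compounds shown here, since no measured step exists to size such a change, the expectation rests on compound 2 alone. The step is expected to be none beyond the scatter, leaving compound 3 at the ceiling of this assay: a step that the limit leaves unreadable from compound 2 to compound 3. Compound 3 is estimated at 1000000 nM, within 500000 nM to 2000000 nM.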

Compound 3, solubility: > 1000000 nM
Compound 3: no number, only a limit; the forecaster's own chance of this, stated with the estimate: 85%; the middle value sits exactly at the limit.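

Among these compounds, compound 2 and compound 3 both return limits in this assay rather than numbers, so no step between them can be read. The compounds shown leave open how far the solubility of each lies past its limit, and whether oxan-4-yl in place of isopropyl on an aromatic carbon makes any difference.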